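A trifluoromethyl group on a short-lived compound

A few compounds are considered here, and "the series" means these few. Any claim that something is new, unique, unknown or untested is made for them only; others in the source may bear on it.

For the measured compounds named here, in an ADME assay on microsomes from liver (Homo sapiens) for metabolic stability (a higher number here means that the compound lasts longer, a lower number that the compound disappears faster), only two compounds have numbers so far. Compound 1 (`CN1C(=O)COc2nc(Nc3cc4c(cn3)ncn4CC3CC3)ccc21`) gives 1.55 h. Compound 2 (`CN1C(=O)COc2cc(Nc3ccc4ncn(CC5CC5)c4n3)cnc21`) gives 0.233 h, the lower of the two, and the gap between them lies beyond the usual scatter of repeat measurements. These two compounds differ in more than one place, so their gap cannot be pinned on any single change.

Compound 3 (`CN1C(=O)COc2cc(Nc3cc(C(F)(F)F)c4ncn(CC5CC5)c4n3)cnc21`) has not yet been measured. It is compound 2 with trifluoromethyl in place of hydrogen on an aromatic carbon, opposite the ring nitrogen: trifluoromethyl in place of hydrogen on an aromatic carbon. Going by the values given here, no pair of measured compounds shows what a single change does in this assay, so any expectation here is loose and the range must stay wide. Among the compounds with values here, the only close anchor is compound 2 at 0.233 h, so the estimate starts there and leans only slightly upward. The estimated step is a 1.5-fold higher number from compound 2 to compound 3 (0.18 log units; within the scatter), a modest rise that is expected to stay within the scatter. For compound 3 the expected half-life is 0.35 h, with an estimated range from 0.15 h to 0.9 h.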

Compound 3, half-life: 1.05 h
Estimate against measurement, compound 3: 3.0-fold (0.48 log units) below, and the stated range ends below it.
By their numbers in this assay, from the lowest: compound 2; then compounds 3 and 1 (each within the scatter of the next).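

In this assay, for the compounds shown here, this is the first single change that can be read on its own. Trifluoromethyl in place of hydrogen on an aromatic carbon, opposite the ring nitrogen, gives a 4.5-fold higher number from compound 2 to compound 3 (0.65 log units; beyond the scatter). This step lies beyond the usual scatter of repeat measurements. Nothing measured here bears on why the half-life changes at this position.

From the compounds shown here alone, a single step at a single carbon cannot separate the effect of trifluoromethyl from that of any substitution there, so it remains open whether methyl, a lone fluorine, chlorine or a nitrile on the same carbon would move the number as far, less far or the other way. It also remains open whether trifluoromethyl would give a similar step on the core of compound 1, which differs from compound 2 in more than one place and has no matching trifluoromethyl partner among the compounds shown.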